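The compounds below may be only part of what the source reports. "The series", "measured", "known", "first", "only" and "open" are said of these compounds alone.

Compound 2 `COC(=O)c1cccc(CSc2nc3ccccc3n2CC(=O)O)c1` gives 450 nM in an assay on HEK293 cells for displacement of a labelled ligand from prostaglandin D2 receptor 2 (Homo sapiens) (on this read-out lower numbers stand for stronger inhibition and higher numbers for weaker inhibition), standing within the scatter of compound 1 `O=C(O)Cn1c(SCc2cccc(Br)c2)nc2ccccc21`, which in this assay gives 370 nM; the step of a 1.2-fold higher number from compound 1 to compound 2 (0.09 log units; within the scatter) is the only one measured. Compound 3 `CC(=O)c1cccc(CSc2nc3ccccc3n2CC(=O)O)c1` differs from compound 2 by methyl in place of methoxy on a carbonyl carbon. Among the compounds with values here, no measured step touches the carbonyl substituent itself, and the one step in hand, which swaps the whole aromatic substituent, was small, so compound 3 is expected to show no step beyond the scatter: a 1.1-fold higher number from compound 2 to compound 3 (0.05 log units; within the scatter). Compound 3 is estimated at 500 nM, within a range from 200 nM to 1300 nM.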

Compound 3, half-maximal inhibitory concentration: 230 nM
Estimate against measurement, compound 3: 2.2-fold (0.34 log units) above; the range from low to high includes it.
By their numbers in this assay, from the lowest: compounds 3, 1 and 2 (each within the scatter of the next).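

In this assay, methyl in place of methoxy on the carbonyl carbon gives a 2.0-fold lower number from compound 2 to compound 3 (0.29 log units; within the scatter) and so, at this first change to the carbonyl substituent itself, the read-out stays within the scatter. Acetyl in place of bromo on an aromatic carbon gives a 1.6-fold lower number from compound 1 to compound 3 (0.21 log units; within the scatter) in the same way, so bromo, methoxycarbonyl and acetyl are not told apart here. No independent evidence bears on these results. As far as these compounds go, whether an amine or a longer chain on the carbonyl carbon would shift the number beyond the scatter remains open.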